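This account rests on a few compounds, and the source may have more. Where it says the series, first, only, none or still open, it means among the compounds named here.

Compound 1, `COc1ccc(OC(=O)Nc2ccc([Se]C#N)cc2)cc1`, bears a methoxy group. In a functional assay on HTB-54 cells (Homo sapiens) for cytotoxicity, read by MTT assay, with a stated time of 72 h (on this read-out lower numbers stand for stronger inhibition of growth and higher numbers for weaker inhibition of growth), compound 1 gives 48500 nM, which stands second highest of the three numbers shown, though all three lie within the scatter of one another: compound 2, `CCCOC(=O)Nc1ccc([Se]C#N)cc1`, gives 51900 nM, and compound 3, `CCCCOC(=O)Nc1ccc([Se]C#N)cc1`, gives 43400 nM. Compound 4, `N#C[Se]c1ccc(NC(=O)Oc2ccc(F)cc2)cc1`, differs from compound 1 by fluoro in place of methoxy on an aromatic carbon. Within the data shown here, the only measured step, a 1.2-fold lower number from compound 2 to compound 3 (0.08 log units; within the scatter), concerns a saturated chain carbon and not the aromatic ring, so no measured step bears directly on this change. With all three numbers close together, no step beyond the scatter is expected in this assay. Compound 4 is therefore estimated at 45000 nM, expected to fall between 20000 nM and 100000 nM, a step of a 1.1-fold lower number from compound 1 to compound 4 (0.03 log units; within the scatter).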

Compound 4, concentration for total growth inhibition: 48400 nM
Estimate against measurement, compound 4: 1.1-fold (0.03 log units) below; the range from low to high includes it.
By their numbers in this assay, from the lowest: compounds 3, 4, 1 and 2 (each within the scatter of the next).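

Fluoro in place of methoxy on an aromatic carbon gives a 1.0-fold lower number from compound 1 to compound 4 (0.00 log units; within the scatter) in this assay. Among these compounds, this is the first look at the ring, as the earlier step concerned only a saturated chain: para to a large group, fluoro with one heavy atom and no hydrogen-bond acceptor cannot be told apart from methoxy with two heavy atoms and one acceptor. No measurement is at hand that could explain this result.

From the compounds shown here alone, whether an amine or a carboxylic acid at this ring position would give a step beyond the scatter remains open.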